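Swapping the benzyl substituent on the core of compound 2

The compounds below may be only part of what the source reports. "The series", "measured", "known", "first", "only" and "open" are said of these compounds alone.

Compound 1 `Cc1cccc(Cc2c(C(N)=O)c3cc(O[C@H]4CC[C@@H](C(=O)O)CC4)ccc3n2C)c1` and compound 2 `Cc1ccccc1Cc1nc2cc(O[C@H]3CC[C@@H](C(=O)O)CC3)ccc2n1C` were both tested in an assay on isolated protein for inhibition of Long-chain-fatty-acid--CoA ligase 1 (Homo sapiens), read by mass spectrometry, with a stated time of 90 min, in the presence of a further agent that is not named here; a lower number here means a stronger inhibitor, a higher number a weaker inhibitor. In this assay compound 1 gives 600 nM, while compound 2 gives 7800 nM, the higher of the two numbers and well beyond the scatter from compound 1. Compound 3 `Cn1c(Cc2ccc3c(c2)OCC3)nc2cc(O[C@H]3CC[C@@H](C(=O)O)CC3)ccc21` differs from compound 2 by one change: a group of 9 heavy atoms (8 carbon, 1 oxygen; one five-membered non-aromatic ring with 1 hetero atom, one six-membered aromatic ring of carbon only) in place of a group of 7 heavy atoms (7 carbon; one six-membered aromatic ring of carbon only), on a saturated chain carbon bound to an aromatic carbon. Among the measured compounds shown here, no measured pair tracks this change, so only a modest step is expected, in either direction or none beyond the scatter. For compound 3 the expected step is a 1.6-fold lower number from compound 2 to compound 3 (0.19 log units; within the scatter), giving an estimate of 5000 nM with a range from 1500 nM to 16000 nM.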

Compound 3, half-maximal inhibitory concentration: 13 nM
Compound 3: middle estimate off by 380-fold (2.59 log units), on the high side; the whole stated range lies above it.
By their numbers in this assay, from the lowest: compound 3; then compound 1; then compound 2.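

In this assay, the group on this saturated chain carbon turns out to have a strong hold on the number: putting the group with a five-membered non-aromatic ring with 1 hetero atom in place of 2-methylphenyl gives a 600-fold lower number from compound 2 to compound 3 (2.78 log units; beyond the scatter). Compounds 1 and 2 differ in more than one place, so they could not isolate this position. No measurement given here explains the size of this step. On these data alone, it remains open whether the ring oxygen is needed, and whether a methoxy group on the phenyl ring or an all-carbon five-membered ring would give a similar step.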